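Nitro for Methyl: Expected Cytotoxicity of Compound 3

A few compounds are considered here, and "the series" means these few. Any claim that something is new, unique, unknown or untested is made for them only; others in the source may bear on it.

Compound 1, `Cc1cccc(Cn2cc(COc3ccc4c(=O)ccoc4c3)nn2)c1`, gives > 100000 nM in a functional assay on SGC-7901 cells (Homo sapiens) for cytotoxicity, read by MTT assay, with a stated time of 48 h; on this read-out higher numbers stand for weaker inhibition and lower numbers for stronger inhibition.
Compound 2, `O=c1ccoc2cc(OCc3cn(Cc4ccc(F)cc4)nn3)ccc12`, gives > 100000 nM in this assay.

Compound 1 stands at a limit of this assay rather than at a number, so its place among the measured compounds cannot be fixed more closely. Compound 2 also sits at a limit. For the measured compounds named here, the only measured step, a step that the two limits leave unreadable from compound 1 to compound 2, is therefore unreadable in size and direction; both values rest at the limit of > 100000 nM in this assay, at which 2 of the 2 values shown sit.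

Compound 3, `O=c1ccoc2cc(OCc3cn(Cc4cccc([N+](=O)[O-])c4)nn3)ccc12`, differs from compound 1 by nitro in place of methyl on an aromatic carbon. Going by the values given here, nothing measured here reads on a change at an aromatic carbon of the six-membered carbon ring, and the single measured step gives no size to lean on. Among the compounds with values here, the only expectation the numbers support is that compound 3 remains at the same limit as compound 1, since compound 1 gives > 100000 nM and compound 2, after a change at the same part of the molecule, gives > 100000 nM.

Compound 3 is thus expected to show no step beyond the scatter, a number no higher from compound 1 to compound 3 (the limit leaves the size open), and is estimated at 100000 nM, with a range from 30000 nM to 300000 nM.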

Compound 3, half-maximal inhibitory concentration: > 100000 nM
Compound 3: a limit, no number; the forecaster's own chance of this, stated with the estimate: 80%; the middle value sits exactly at the limit.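

No new step can be read among compound 1, compound 2 and compound 3, since each rests at a limit of the assay and not at a number: the limit of > 100000 nM in this assay, at which 3 of the 3 values shown sit.

The compounds shown leave open whether any of the three truly differs from the others in this assay, and whether any substituted phenyl group on the shared core gives a readable value.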